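Swapping 3-Chlorophenyl for Methoxycarbonyl on the Shared Core

A few compounds are considered here, and "the series" means these few. Any claim that something is new, unique, unknown or untested is made for them only; others in the source may bear on it.

The three measured compounds and their results in an assay on microsomes from brain for inhibition of Fatty-acid amide hydrolase 1 (Rattus norvegicus), read by fluorescence and HPLC, with a stated time of 60 min (on this read-out lower numbers stand for stronger inhibition and higher numbers for weaker inhibition), are:
compound 1, `CCCCCCCCc1ccc(OCC(=O)Cn2nnc(C)n2)cc1`, 27 nM
compound 2, `CCCCCCCCc1ccc(OCC(=O)Cn2nnc(-c3cccc(Cl)c3)n2)cc1`, 24 nM
compound 3, `CCCCCCCCc1ccc(OCC(=O)Cn2nnc(-c3ccncc3)n2)cc1`, 24 nM

Compound 2 sits level with compound 3 at the digits given, and the two together hold the lowest numbers of the set; its nearest neighbour is compound 3, with no change at the digits printed from compound 2 to compound 3 (within the scatter), and its furthest is compound 1, which gives 27 nM in this assay, a gap that also lies within the scatter.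

The step now under consideration leads from compound 2 to compound 4, `CCCCCCCCc1ccc(OCC(=O)Cn2nnc(C(=O)OC)n2)cc1`. The change is methoxycarbonyl in place of 3-chlorophenyl on an aromatic carbon.

Going by the values given here, three measured steps touch the same aromatic carbon of the shared core. From compound 1 to compound 2, a 1.1-fold lower number from compound 1 to compound 2 (0.05 log units; within the scatter); from compound 1 to compound 3, a 1.1-fold lower number from compound 1 to compound 3 (0.05 log units; within the scatter); and from compound 2 to compound 3, no change at the digits printed from compound 2 to compound 3 (within the scatter). Methyl, 3-chlorophenyl and pyridin-4-yl at this position all leave the number essentially where it was. Among the compounds with values here, no measured compound carries methoxycarbonyl or any group of its kind there, so the evidence for the new group is indirect, but on the three steps seen no step beyond the scatter is expected in this assay.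

Compound 4 is therefore estimated at 30 nM, in a range from 10 nM to 100 nM, which means an expected step of a 1.3-fold higher number from compound 2 to compound 4 (0.10 log units; within the scatter).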

Compound 4, half-maximal inhibitory concentration: 88 nM
Estimate against measurement, compound 4: 2.9-fold (0.47 log units) below; the range from low to high includes it.
By their numbers in this assay, from the lowest: compounds 2, 3 and 1 (each within the scatter of the next); then compound 4.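

Across methyl, 3-chlorophenyl and pyridin-4-yl, the aromatic carbon between two ring nitrogen atoms had shown no step beyond the scatter in (this assay), but methoxycarbonyl shows that the number at this position can move, with (a 3.7-fold higher number from compound 2 to compound 4 (0.56 log units; beyond the scatter)), (a 3.7-fold higher number from compound 3 to compound 4 (0.56 log units; beyond the scatter)) and (a 3.3-fold higher number from compound 1 to compound 4 (0.51 log units; beyond the scatter)). All three steps are modest and lead the same way, so among the compounds shown, methoxycarbonyl alone stands apart from the other three groups, which remain within the scatter of one another. Against 3-chlorophenyl, the change removes an aromatic ring and brings in a double bond outside aromatic rings and two hydrogen-bond acceptors, yet nothing available ties the higher number to any one of these differences.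

The compounds shown leave open whether the shift goes with the carbonyl itself or with the methoxy part of the group, since only this one group of its kind appears at this carbon. From the compounds shown here alone, how an acetyl group, a primary amide or a carboxylic acid on the same carbon would read in (this assay) also remains open, and these would help separate the two parts.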